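The source may report more compounds than this note shows. Statements on the series, on what has been measured and on what is new or still open speak of the compounds shown alone.

Compound 3 `CCc1cccc2c(OC)c(-c3occ(C)c3C(=S)OC)ccc12` carries a methyl thioester on the five-membered ring of the shared core. In a functional assay on KB cells (Homo sapiens) for cytotoxicity, read by MTT assay, with a stated time of 72 h (a lower number here means that less compound is needed, a higher number that more compound is needed for the effect), compound 3 gives 4.3 ug/mL. For the measured compounds named here, only two numbers are known here, and the one for compound 3 and the one for compound 1 `CCOC(=O)c1c(C)coc1-c1ccc2c(CC)cccc2c1OC`, an ethyl ester in that position, lie within the scatter of each other: compound 1 gives 2.2 ug/mL, and the step of a 2.0-fold higher number from compound 1 to compound 3 (0.29 log units; within the scatter) is small. Compound 2 `CCCOC(=O)c1c(C)coc1-c1ccc2c(CC)cccc2c1OC`, the propyl ester, gives in this assay only the limit > 10 ug/mL. One value is thus (the limit of > 10 ug/mL in this assay, at which 1 of the 3 values shown sits). The steps of an at least 4.5-fold higher number from compound 1 to compound 2 (0.65 log units; beyond the scatter) and an at least 2.3-fold lower number from compound 2 to compound 3 (0.36 log units; beyond the scatter) are the larger ones.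

Compound 4 `CCc1cccc2c(OC)c(-c3occ(C)c3C(=O)NC)ccc12` is reached by a group of 4 heavy atoms (2 carbon, 1 nitrogen, 1 oxygen; no ring) in place of a group of 4 heavy atoms (2 carbon, 1 oxygen, 1 sulfur; no ring), on an aromatic carbon. The closest comparison is the exchange of the ester for the thioester, which moved the number little, and the exchange from the propyl ester, which moved it modestly; a new group of the same size is therefore expected to give no step beyond the scatter. Compound 4 is estimated at 4.5 ug/mL, between 1.8 ug/mL and 12 ug/mL. The expected step is a 1.0-fold higher number from compound 3 to compound 4 (0.02 log units; within the scatter).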

Compound 4, concentration for half-maximal effect: > 10 ug/mL
Compound 4 gave a limit, no number; the forecaster's own chance of this, stated with the estimate: 25%; middle value at least 2.2-fold (0.34 log units) from the limit.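

This position on the five-membered aromatic ring does not accept every group of this size: putting the methylcarbamoyl group in place of the thioester gives an at least 2.3-fold higher number from compound 3 to compound 4 (0.36 log units; beyond the scatter). Measured against the ethyl ester, the same group gives an at least 4.5-fold higher number from compound 1 to compound 4 (0.65 log units; beyond the scatter). Until now only the propyl ester had moved the number beyond the scatter, so compound 4 shows that a chain length on the carbonyl is not the only thing that matters here: a nitrogen bearing a hydrogen-bond donor, in place of oxygen or sulfur, also does so, although the result for compound 4 is a limit and not a number.

As far as these compounds go, the step between compound 2 and compound 4 cannot be read, as both results stop at the same point: the limit of > 10 ug/mL in this assay, at which 2 of the 4 values shown sit. Whether the amide hydrogen itself matters stays open, and a dimethylcarbamoyl group or a carboxylic acid at this position would speak to that.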